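Cyclobutyl amide in place of hydroxycyclobutyl on the shared core

A few compounds are considered here, and "the series" means these few. Any claim that something is new, unique, unknown or untested is made for them only; others in the source may bear on it.

Two analogues of the shared core carry numbers in an assay on isolated protein for inhibition of protein kinase C theta type (Homo sapiens), read by TR-FRET, with a stated time of 2 h; on this read-out lower numbers stand for stronger inhibition and higher numbers for weaker inhibition. Compound 1 `N#Cc1cnc(NCc2cnccc2C(F)(F)F)cc1N[C@H]1C[C@@H](O)C1` gives 500 nM and stands at the higher of the two numbers. Compound 2 `N#Cc1cnc(NCc2ccccc2C(F)(F)F)cc1N[C@H]1CC[C@@H](O)CC1` gives 140 nM in this assay, a lower number than compound 1; the two differ in more than one place, so the pair says nothing about any single change. Compound 3 `CC1(C)[C@H](Nc2cc(NCc3cnccc3C(F)(F)F)ncc2C#N)C[C@H]1C(N)=O` is not yet measured in this assay. It differs from compound 1 at the nitrogen on the aromatic ring: 3-carbamoyl-2,2-dimethylcyclobutyl in place of 3-hydroxycyclobutyl on a nitrogen on an aromatic ring. Among the measured compounds shown here, the amide and the two methyl groups that enter are not represented among the measured compounds, so no step on record speaks to this change. The expectation for compound 3 rests only on the shared core and on the fact that compound 1 gives 500 nM as a starting point; a moderate move to a lower number is expected, a 3.3-fold lower number from compound 1 to compound 3 (0.52 log units; beyond the scatter), but with wide uncertainty. Compound 3 is estimated at 150 nM in this assay, within a range of 40 nM to 600 nM.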

Compound 3, half-maximal inhibitory concentration: 140 nM
The estimate for compound 3 lay 1.1-fold (0.03 log units) above the measured number, and the stated range covers the measured number.
By their numbers in this assay, from the lowest: compounds 2 and 3 (each within the scatter of the next); then compound 1.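

Among the compounds shown here, the step from 3-hydroxycyclobutyl to 3-carbamoyl-2,2-dimethylcyclobutyl on a nitrogen on an aromatic ring is the first single-place comparison, and in this assay it reads a 3.6-fold lower number from compound 1 to compound 3 (0.55 log units; beyond the scatter), a modest step beyond the scatter. The position therefore tolerates growth from 5 to 9 heavy atoms with the four-membered carbon ring retained, and the hydroxyl of compound 1 is not needed for a lower number on this core. The data on hand give no independent measurement that accounts for the step, and its size alone cannot separate the contributions of the amide and the two methyl groups.

The change brings in the carbamoyl group and the two methyl groups together, so the compounds shown leave open whether either alone accounts for the step, as a 3-carbamoylcyclobutyl or a 3-hydroxy-2,2-dimethylcyclobutyl group would test. Also open, as far as these compounds go, are how a carboxylic acid or an amine would read in place of the amide at this position, and how much the two defined stereocentres of the entering group matter.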